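Aryl ureas in rice: a methyl added to compound 3

The compounds below may be only part of what the source reports. "The series", "measured", "known", "first", "only" and "open" are said of these compounds alone.

Measured so far in an ADME assay on the whole organism with Oryza sativa as the target, tested at 1 uM; a lower number here means a stronger effect, a higher number a weaker effect of the compound at the concentration tested:
compound 1 `CCc1ccccc1NC(=O)N[C@H](C)c1ccccc1` gives 100%
compound 2 `C[C@@H](NC(=O)Nc1ccccc1C(F)(F)F)c1ccccc1` gives 95%
compound 3 `C[C@@H](NC(=O)Nc1ccccc1F)c1ccccc1` gives 95%

Compound 3 stands level with compound 2, and the two together give the lowest of the three numbers; the step of no change at the digits printed from compound 2 to compound 3 (within the scatter) and the step of a number 5 percentage points lower from compound 1 to compound 3 (within the scatter) show how close all three lie. Compound 4 `Cc1ccc(NC(=O)N[C@H](C)c2ccccc2)c(F)c1` differs from compound 3 by methyl in place of hydrogen on an aromatic carbon. Among the measured compounds shown here, no measured step puts a methyl in place of hydrogen. The steps that exist, a number 5 percentage points lower from compound 1 to compound 2 (within the scatter) and a number 5 percentage points lower from compound 1 to compound 3 (within the scatter), each swap one group on an aromatic carbon and stay within the scatter. A step of no more than the scatter is therefore expected in this assay, namely a number 2 percentage points lower from compound 3 to compound 4 (within the scatter). Compound 4 is expected to give 93%, in a range from 80% to 100%.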

Compound 4, a percentage reported as activity, at one concentration (the size of the read-out at that concentration, not a potency): 99%
Estimate against measurement, compound 4: 6 percentage points below; the range from low to high includes it.
By their numbers in this assay, from the lowest: compounds 2, 3, 4 and 1 (each within the scatter of the next).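

In this assay, methyl in place of hydrogen on the aromatic carbon para to a large group and meta to a fluoro group gives a number 4 percentage points higher from compound 3 to compound 4 (within the scatter). This is the first step shown at this position and the first that adds a group to a hydrogen-bearing carbon instead of swapping one group for another, and like the earlier swaps it stays within the scatter. Nothing measured here bears on the reason for this result.

Going by these compounds, whether an amine, a carboxylic acid or a longer chain at this position would give a step beyond the scatter stays open. So does whether any change to the shared core can do so in this assay.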